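Two measured inhibitors and a third awaiting its number

The compounds below may be only part of what the source reports. "The series", "measured", "known", "first", "only" and "open" are said of these compounds alone.

Measured so far:
- compound 1, `O=C(NCc1cc(Cl)ccc1-n1cnnn1)[C@@H]1C[C@@H]2C[C@@H]2N1C(=O)[C@H](O)CC1CC1`: 1700 nM
- compound 2, `O=C(NCc1cc(Cl)ccc1-n1cnnn1)[C@@H]1CC=NN1C(=O)[C@H](O)c1ccccc1`: 840 nM

The read-out throughout is a functional assay on a cell-free system (plasma, Homo sapiens), with a stated time of 3 min; a lower number here means a stronger inhibitor, a higher number a weaker inhibitor. In this assay compound 1 gives 1700 nM, while compound 2 gives 840 nM. Of the two numbers, that of compound 2 is the lower; compound 1 lies at a higher number, and the gap between them is beyond the usual scatter. Within the data shown here, no single-change pair between measured compounds is available, so the two values show only that compound 2 is the stronger of this small set.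

The next compound is compound 3, `CC(C)(C)OC[C@@H](O)C(=O)N1N=CC[C@H]1C(=O)NCc1cc(Cl)ccc1-n1cnnn1`. It departs from compound 2 by one change: (tert-butoxy)methyl in place of phenyl on a saturated chain carbon bound to a carbonyl carbon and an oxygen on a saturated carbon. Among the measured compounds shown here, nothing among the measured compounds tells how the position on the saturated chain carbon bound to a carbonyl carbon and an oxygen on a saturated carbon tolerates such an exchange. For the measured compounds named here, with no comparable step to lean on, only a modest shift from compound 2 to compound 3 is expected, a 1.8-fold higher number from compound 2 to compound 3 (0.25 log units; within the scatter), leaning toward a somewhat higher number but possibly within the scatter. Compound 3 is therefore estimated at 1500 nM, in a range from 400 nM to 5000 nM.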

Compound 3, half-maximal inhibitory concentration: 750 nM
Estimate against measurement, compound 3: 2.0-fold (0.30 log units) above; measured number inside the range.
By their numbers in this assay, from the lowest: compounds 3 and 2 (each within the scatter of the next); then compound 1.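

In this assay, putting (tert-butoxy)methyl in place of phenyl on a saturated chain carbon bound to a carbonyl carbon and an oxygen on a saturated carbon gives a 1.1-fold lower number from compound 2 to compound 3 (0.05 log units; within the scatter) and so leaves the number unchanged within the scatter. This is the first comparison at this position among the compounds shown, and it indicates that a six-membered aromatic ring of carbon only is not needed here to keep a number of this size: a group with no ring and one hydrogen-bond acceptor, holding the same count of heavy atoms, reads the same. Nothing measured here accounts for why the two groups read alike.

Both groups compared hold the same count of heavy atoms, so the compounds shown leave open how a much smaller group such as methyl, or a longer chain, would read on this carbon. Also open, from the compounds shown here alone, is whether an amine or a carboxylic acid in this place would keep the number, and whether the same exchange would read alike on the core of compound 1.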